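The source may report more compounds than this note shows. Statements on the series, on what has been measured and on what is new or still open speak of the compounds shown alone.

Measured so far:
compound 1, `CC/C=C/C(=O)Nc1cc2c(N3CCc4ccccc43)ncnc2cc1OC`: 5890 nM
compound 2, `C/C=C/C(=O)Nc1cc2c(N3CCc4ccccc43)ncnc2cc1O[C@@H]1CCOC1`: 5220 nM

In a functional assay on PC-3 cells (Homo sapiens) for antiproliferative activity, read by MTT assay, with a stated time of 72 h (a lower number here means a stronger inhibitor, a higher number a weaker inhibitor), compound 1 gives 5890 nM, and in this assay compound 2 gives 5220 nM. Compound 2 holds the lower of the two numbers, but the gap to compound 1 lies within the scatter, so the two values show no ordering.

Compound 3, `CC/C=C/C(=O)Nc1cc2c(N3CCc4ccccc43)ncnc2cc1O[C@@H]1CCOC1`, is not yet measured. Against compound 2 it carries one change: methyl in place of hydrogen on a saturated chain carbon bound to a double-bonded chain carbon. For the measured compounds named here, no step between measured compounds bears on this change, so nothing measured tells its direction or size. With the two known values sitting close together, the working expectation for compound 3 in this assay is a step of no size beyond the scatter, a 1.0-fold lower number from compound 2 to compound 3 (0.02 log units; within the scatter), in either direction. On that basis compound 3 is estimated at 5000 nM, with a range from 2500 nM to 10000 nM.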

Compound 3, half-maximal inhibitory concentration: 9590 nM
The estimate for compound 3 lay 1.9-fold (0.28 log units) below the measured number; low and high end bracket the measured number.
By their numbers in this assay, from the lowest: compounds 2, 1 and 3 (each within the scatter of the next).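

In this assay, methyl in place of hydrogen on a saturated chain carbon bound to a double-bonded chain carbon, which turns prop-1-en-1-yl into but-1-en-1-yl, gives a 1.8-fold higher number from compound 2 to compound 3 (0.26 log units; within the scatter) and so does not separate the two compounds. For the compounds shown here, this is the first direct reading at this position, and the second position now has one too: oxolan-3-yl in place of methyl on an oxygen on an aromatic ring gives a 1.6-fold higher number from compound 1 to compound 3 (0.21 log units; within the scatter) and again separates nothing. No supporting data bear on either step.

Open, going by these compounds, is whether a longer chain such as pent-1-en-1-yl, or an amine on that chain, would give a step beyond the scatter. Also open, on these data alone, is whether any group other than methyl or oxolan-3-yl on that oxygen, such as 2-methoxyethyl, would do so.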